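Swapping bromo for hydroxy on a fused-ring compound

The source may report more compounds than this note shows. Statements on the series, on what has been measured and on what is new or still open speak of the compounds shown alone.

Measured in a functional assay on MCF7 cells (Homo sapiens) for antiproliferative activity, read by MTT assay, with a stated time of 48 h; a higher number here means a weaker inhibitor, a lower number a stronger inhibitor:
Compound 1 `O=c1cc(-n2cc(CSc3ccccc3)nn2)c2cc(Br)ccc2o1`: 36800 nM
Compound 2 `O=c1cc(-n2cc(COc3ccc(F)cc3)nn2)c2cc(Br)ccc2o1`: 7000 nM

Compound 2 holds the lower of these two numbers, which makes it the stronger inhibitor so far. Compound 3 `O=c1cc(-n2cc(COc3ccc(F)cc3)nn2)c2cc(O)ccc2o1` differs from it in one place, with hydroxy in place of bromo on an aromatic carbon.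

Among the measured compounds shown here, only one measured step exists: a 5.3-fold lower number from compound 1 to compound 2 (0.72 log units; beyond the scatter). It swapped phenylsulfanyl for 4-fluorophenoxy on a saturated chain carbon, and bromo stayed in place throughout, so no measurement tests the new change directly. That step serves only as a rough yardstick of size. In this assay, a modest rise is expected, though the direction is uncertain. The expected step is a 2.0-fold higher number from compound 2 to compound 3 (0.30 log units; within the scatter). Compound 3 is estimated at 14000 nM, with an expected range of 3500 nM to 50000 nM.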

Compound 3, half-maximal inhibitory concentration: 4620 nM
Estimate against measurement, compound 3: 3.0-fold (0.48 log units) above, and the stated range covers the measured number.
By their numbers in this assay, from the lowest: compounds 3 and 2 (each within the scatter of the next); then compound 1.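

In this assay, hydroxy in place of bromo on the aromatic carbon gives a 1.5-fold lower number from compound 2 to compound 3 (0.18 log units; within the scatter), so at this position the swap leaves no effect that can be told apart from the scatter. This is the only test of this position among the compounds shown, since the earlier step changed only the group on the chain, and here a hydrogen-bond donor and acceptor enter where bromo had neither without separating compound 2 from compound 3. No measurement at hand offers an explanation for this result.

Going by these compounds, whether the same holds for other groups on this carbon stays open, and an amine or a methoxy there would extend the test. Hydroxy is also seen only alongside 4-fluorophenoxy, so its behaviour alongside phenylsulfanyl remains unknown.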